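The source may report more compounds than this note shows. Statements on the series, on what has been measured and on what is new or still open speak of the compounds shown alone.

Measured compounds:
- compound 1 `O=C1C[C@@H](O[C@H]2O[C@H](CO)[C@@H](O)[C@H](O)[C@H]2O)CN1`: 89000 nM
- compound 2 `O=C1C[C@H](O[C@H]2O[C@H](CO)[C@@H](O)[C@H](O)[C@H]2O)CN1`: 80900 nM

In a functional assay on RAW264.7 cells (Mus musculus) for inhibition, read by Griess assay, with a stated time of 24 h (a higher number here means a weaker inhibitor, a lower number a stronger inhibitor), compound 1 gives 89000 nM, the higher of the two numbers recorded so far. Compound 2 gives 80900 nM. Among the measured compounds shown here, the one measured step, a 1.1-fold lower number from compound 1 to compound 2 (0.04 log units; within the scatter), rests on (the fact that compounds 1 and 2 differ only in the configuration as drawn), so it tells only that inverting that ring stereocentre leaves the number essentially unchanged.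

Compound 3 `O=C1C[C@@H](O[C@H]2O[C@H](CO)[C@@H](O)[C@H](O)[C@H]2O)CN1Cc1ccccc1` differs from compound 1 by benzyl in place of hydrogen on an amide-type nitrogen in a ring. For the measured compounds named here, no measured pair touches the amide-type nitrogen in the ring, and the single measured step concerns a stereocentre rather than a substituent, so it offers no direct guide to this change. The expectation therefore rests on compound 1 itself, with wide uncertainty in both directions. The working estimate for compound 3 in this assay is 70000 nM, with a range from 15000 nM to 300000 nM. This estimate corresponds to an expected step of a 1.3-fold lower number from compound 1 to compound 3 (0.10 log units; within the scatter), that is, a number close to that of compound 1 and not expected to move beyond the scatter.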

Compound 3, half-maximal inhibitory concentration: 72500 nM
Beside the measured number, compound 3's estimate is 1.0-fold (0.02 log units) below it; the measured number falls inside the stated range.
By their numbers in this assay, from the lowest: compounds 3, 2 and 1 (each within the scatter of the next).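

In this assay the amide-type nitrogen in the ring now has a measured substituent, and benzyl in place of hydrogen gives a 1.2-fold lower number from compound 1 to compound 3 (0.09 log units; within the scatter). Among the compounds shown here, the earlier step touched only a ring stereocentre, so this is the first reading at this nitrogen: adding 7 heavy atoms and one six-membered aromatic ring of carbon only leaves the number in the same high range as that of compound 1, with no gain in inhibition beyond the scatter. Nothing on record bears on why this substitution leaves the number where it is.

Open, as far as these compounds go, is whether any other group on this nitrogen moves the number beyond the scatter, for example a longer chain such as phenethyl, a chain ending in an amine or a carboxylic acid, or a benzyl ring carrying chlorine or methoxy. Also open, from the compounds shown here alone, is whether benzyl behaves the same way on the core of compound 2, with the opposite drawn configuration at the ring stereocentre, and whether changes to the sugar portion shift the number at all.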